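The compounds below may be only part of what the source reports. "The series", "measured", "known", "first", "only" and "open" are said of these compounds alone.

Compound 1 `CCCCCCCCc1ccc(OCC(=O)Cn2nnc(-c3cccc(Cl)c3)n2)cc1`: 24 nM
Compound 2 `CCCCCCCCc1ccc(OCC(=O)Cn2nnc(-c3cccc(C(=O)OC)c3)n2)cc1`: 34 nM
Compound 3 `CCCCCCCCc1ccc(OCC(=O)Cn2nnc(-c3ccncc3)n2)cc1`: 24 nM

All three compounds share one core and differ only in the aromatic group attached to it; all three were measured in an assay on microsomes from brain for inhibition of Fatty-acid amide hydrolase 1 (Rattus norvegicus), read by fluorescence and HPLC, with a stated time of 60 min; on this read-out lower numbers stand for stronger inhibition and higher numbers for weaker inhibition. Compound 2 gives the highest of the three numbers, but neither of its neighbours lies far away. The step of a 1.4-fold higher number from compound 1 to compound 2 (0.15 log units; within the scatter) and the step of a 1.4-fold lower number from compound 2 to compound 3 (0.15 log units; within the scatter) both fall inside the scatter of repeated measurements, as does the step of no change at the digits printed from compound 1 to compound 3 (within the scatter). On these numbers the three compounds cannot be told apart, and the exchange of one aromatic group for another at this position has so far moved the read-out by no more than the method itself does.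

Compound 4 `CCCCCCCCc1ccc(OCC(=O)Cn2nnc(-c3cccs3)n2)cc1` has not yet been measured. It differs from compound 2 in a single place: thiophen-2-yl in place of 3-(methoxycarbonyl)phenyl on an aromatic carbon. The two measured steps that also exchange the group at this place were each inside the scatter, so no step beyond the scatter is expected here either, in either direction. Compound 4 is therefore estimated at 26 nM in this assay, with a range from 10 nM to 70 nM. The expected step is a 1.3-fold lower number from compound 2 to compound 4 (0.12 log units; within the scatter).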

Compound 4, half-maximal inhibitory concentration: 32 nM
Estimate against measurement, compound 4: 1.2-fold (0.09 log units) below; measured number inside the range.
By their numbers in this assay, from the lowest: compounds 1, 3, 4 and 2 (each within the scatter of the next).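

In this assay, the change from a six-membered aromatic ring of carbon only to a five-membered aromatic ring with a sulfur atom leaves the read-out within the scatter: the steps are a 1.1-fold lower number from compound 2 to compound 4 (0.03 log units; within the scatter), a 1.3-fold higher number from compound 3 to compound 4 (0.12 log units; within the scatter) and a 1.3-fold higher number from compound 1 to compound 4 (0.12 log units; within the scatter). The earlier compounds shown here had varied this position only among six-membered aromatic rings, so compound 4 extends the flat picture to a different ring size, and the exchange with compound 2 also removes the methoxycarbonyl group and its double bond outside aromatic rings, with fewer heavy atoms entering than leaving, without a step beyond the scatter. Nothing measured on these compounds offers an explanation for this flat picture.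

As far as these compounds go, all four compounds carry an aromatic ring at this place, so it remains open whether a saturated ring such as cyclohexyl, or a carboxylic acid or an amine on the aromatic ring, would move the number beyond the scatter. From the compounds shown here alone, they also share the same core and the same chain, so how the read-out would respond to a shorter chain remains unknown.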